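Swapping a Secondary Amine for a Sulfonylpiperazine on the Side Chain

This account rests on a few compounds, and the source may have more. Where it says the series, first, only, none or still open, it means among the compounds named here.

Of the compounds shown here, three sharing one core have been measured in an ADME assay on microsomes from liver (Homo sapiens) for metabolic stability, read by LC-MS, tested at 1 uM; on this read-out lower numbers stand for slow clearance and higher numbers for fast clearance. Compound 1 `N[C@H]1CC[C@@H](Oc2ccc([C@H]3CC[C@]4(CC3)OOC3(O4)C4CC5CC(C4)CC3C5)cc2)CC1` gives only a limit, < 7 mL.min-1.g-1. Compound 2 `CC(C)(CN)Oc1ccc([C@H]2CC[C@]3(CC2)OOC2(O3)C3CC4CC(C3)CC2C4)cc1` likewise gives only a limit, < 7 mL.min-1.g-1. Among the compounds with values here, compound 3 `c1cc([C@H]2CC[C@]3(CC2)OOC2(O3)C3CC4CC(C3)CC2C4)ccc1OCCCNC1CCOCC1` is the single compound with a real number, 10 mL.min-1.g-1, and so it is the one firm point from which anything can be measured. The steps of an at least 1.4-fold higher number from compound 1 to compound 3 (0.15 log units; that floor lies within the scatter) and an at least 1.4-fold higher number from compound 2 to compound 3 (0.15 log units; that floor lies within the scatter) are read against the limit (the limit of < 7 mL.min-1.g-1 in this assay, at which 2 of the 3 values shown sit), and since their floors lie inside the usual scatter they give no clear size in either case.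

Compound 4 `CS(=O)(=O)N1CCN(CCCOc2ccc([C@H]3CC[C@]4(CC3)OOC3(O4)C4CC5CC(C4)CC3C5)cc2)CC1` differs from compound 3 in one place: 4-(methylsulfonyl)piperazin-1-yl in place of (oxan-4-yl)amino on a saturated chain carbon, three bonds along the chain from an oxygen on an aromatic ring. Within the data shown here, none of the measured steps exchanges a group at this spot on the chain in a comparable way, and the two steps that do alter this side chain each begin at a limit, so they cannot set a size for this change. Among the measured compounds shown here, with no step to lean on, compound 4 is expected to stay close to compound 3, with no change at the digits printed from compound 3 to compound 4 (within the scatter) as the expected step. The estimate for compound 4 in this assay is 10 mL.min-1.g-1, with a range from 5 mL.min-1.g-1 to 22 mL.min-1.g-1.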

Compound 4, intrinsic clearance in microsomes: 68 mL.min-1.g-1
Estimate against measurement, compound 4: 6.8-fold (0.83 log units) below; the whole stated range lies below it.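

In this assay, within the data shown here, the change at this spot gives a 6.8-fold higher number from compound 3 to compound 4 (0.83 log units; beyond the scatter), the first step on this side chain with a readable size, and it lies beyond the scatter. So the group carried on a saturated chain carbon, three bonds along the chain from an oxygen on an aromatic ring, is not a silent part of these molecules for clearance, even with the shared core left untouched. The earlier steps could not show this, as none of them can be read to a clear size, each resting on a limit: the limit of < 7 mL.min-1.g-1 in this assay, at which 2 of the 4 values shown sit.

Among these compounds, the single step also changes several things at once, with the hydrogen-bond donor of the (oxan-4-yl)amino group gone and a second ring nitrogen and a sulfonyl sulfur brought in, so it cannot point to any one of them. As far as these compounds go, it remains open whether the higher number belongs to the methylsulfonyl group or to the piperazine ring, and a plain piperazine, an N-acetylpiperazine or a morpholine on the same chain would begin to separate the two.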